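This account rests on a few compounds, and the source may have more. Where it says the series, first, only, none or still open, it means among the compounds named here.

Measured compounds:
compound 1 `CCCc1ncn2c(SC)nncc12`; in a functional assay for inhibition, with Homo sapiens as the target (a lower number here means a stronger inhibitor, a higher number a weaker inhibitor), compound 1 gives > 48000 nM, which is a limit of the assay and not a number.
compound 2 `CSc1nncc2c(C)ncn12`; in this assay compound 2 gives > 48000 nM, again a limit of the assay.
compound 3 `CCCc1ncc2cnnc(SC)n12`; in this assay compound 3 gives > 48000 nM, also a limit of the assay.

Compound 1 and compound 2 differ in one place: hydrogen in place of ethyl on a saturated chain carbon bound to an aromatic carbon. The step in this assay from compound 1 to compound 2 is a step that the two limits leave unreadable from compound 1 to compound 2, and its size cannot be read because both ends of it sit at the limit of > 48000 nM in this assay, at which 3 of the 3 values shown sit. Compound 3 shares its atoms with compound 1, joined differently; the difference between the two cores is not broken down here. Of compound 3 in this assay only a limit is known, and the same holds for the two other values shown.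

Compound 4 `CSc1nncc2cnc(C)n12` has not been measured in this assay. From compound 3 it differs by hydrogen in place of ethyl on a saturated chain carbon bound to an aromatic carbon, which is the same change, at the same place, as that from compound 1 to compound 2. Within the data shown here, the step expected in this assay is a step that the limit leaves unreadable from compound 3 to compound 4, and this rests on the fact that the one earlier instance of the change left both compounds at the limit of > 48000 nM in this assay, at which 3 of the 3 values shown sit, so that no shift beyond the limit can be inferred. Compound 4 is therefore expected to give about 70000 nM in this assay, most likely reported only as a limit. The estimated range for compound 4 runs from 20000 nM to 250000 nM.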

Compound 4, half-maximal inhibitory concentration: > 48000 nM
Compound 4: no number, only a limit (the forecaster's own chance of this, stated with the estimate: 85%); the middle value lies beyond the limit too.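

In this assay compound 4 gives > 48000 nM, which is a limit of the assay and not a number. No step can be read between compound 3 and compound 4, since both stand at a limit: the limit of > 48000 nM in this assay, at which 4 of the 4 values shown sit.

The compounds shown leave open whether any compound of this series gives a readable value in this assay, and so what hydrogen in place of ethyl does to that value.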